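A few compounds are considered here, and "the series" means these few. Any claim that something is new, unique, unknown or untested is made for them only; others in the source may bear on it.

Values in a functional assay on K562 cells (Homo sapiens) for antiproliferative activity, read by trypan blue exclusion, with a stated time of 48 h, tested at 10 uM; on this read-out lower numbers stand for less inhibition of growth and higher numbers for more inhibition of growth at the one concentration tested:
- compound 1 `NC(=O)c1cc(Cl)ccc1NC(=O)/C=C/c1ccccc1Br` gives 49%
- compound 2 `NC(=O)c1cc(Cl)ccc1NC(=O)/C=C/c1cccc(Br)c1` gives 27%
- compound 3 `Cc1cccc(/C=C/C(=O)Nc2ccc(Cl)cc2C(N)=O)c1` gives 37.8%
- compound 4 `Cc1ccc(/C=C/C(=O)Nc2ccc(Cl)cc2C(N)=O)cc1` is not yet measured

Compound 3 stands second highest of the three, with a number 11.2 percentage points lower from compound 1 to compound 3 (beyond the scatter) on one side and a number 10.8 percentage points higher from compound 2 to compound 3 (beyond the scatter) on the other. The next change is 4-methylphenyl in place of 3-methylphenyl on a double-bonded chain carbon bound to a double-bonded chain carbon. The two compounds have the same atoms, joined differently. The closest measured precedent is the pair of bromo compounds, a number 22 percentage points lower from compound 1 to compound 2 (beyond the scatter), a modest step showing that the change of group between these two compounds can register in this series. Among the measured compounds shown here, that step gives no direction for the methyl pair, and no measured compound carries a 4-methylphenyl. From the compounds shown here alone, no step beyond the scatter is therefore expected in this assay, although a modest one in either direction remains open. The expected outcome is a number 0.8 percentage points lower from compound 3 to compound 4 (within the scatter) as an estimate. For compound 4 the estimated value is 37%, with an expected range from 22% to 52% on this read-out.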

Compound 4, percent growth inhibition at one concentration: 64%
Beside the measured number, compound 4's estimate is 27 percentage points below it; the measured number lies above the stated range.
By their numbers in this assay, from the lowest: compound 2; then compound 3; then compound 1; then compound 4.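

In this assay, 4-methylphenyl in place of 3-methylphenyl on a double-bonded chain carbon bound to a double-bonded chain carbon gives a number 26.2 percentage points higher from compound 3 to compound 4 (beyond the scatter), so rearranging the same atoms at this position shifts growth inhibition even with the methylphenyl group, where earlier only the bromo pair showed a step. The 4-methylphenyl group also exceeds both bromophenyl groups, with a number 37 percentage points higher from compound 2 to compound 4 (beyond the scatter) and a number 15 percentage points higher from compound 1 to compound 4 (beyond the scatter), which puts compound 4 highest of the four. Nothing available accounts for this rise.

From the compounds shown here alone, it remains open whether an amine or a carboxylic acid in place of the methyl of the 4-methylphenyl group would hold a number of this size. Going by these compounds, with one concentration per compound, how these differences would appear across a range of concentrations also remains open.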